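A Methoxy Group Added to a Chloro-Bearing Analogue

The source may report more compounds than this note shows. Statements on the series, on what has been measured and on what is new or still open speak of the compounds shown alone.

Three compounds have been measured in a functional assay on A549 cells (Homo sapiens) for antiproliferative activity, read by MTT assay, with a stated time of 48 h; a higher number here means a weaker inhibitor, a lower number a stronger inhibitor:

Compound 1, `O=C(/C=C/c1ccccc1)Nc1nnc(-c2ccccc2)s1`: 1.75 ug/mL
Compound 2, `COc1ccc(-c2nnc(NC(=O)/C=C/c3ccccc3)s2)cc1`: 0.68 ug/mL
Compound 3, `O=C(/C=C/c1ccccc1)Nc1nnc(-c2ccc(Cl)cc2)s1`: 2.02 ug/mL

Compound 1 and compound 2 differ only in methoxy in place of hydrogen on an aromatic carbon, and that change gave a 2.6-fold lower number from compound 1 to compound 2 (0.41 log units; beyond the scatter). The core of compound 3 differs from that of compound 1 in chloro in place of hydrogen on an aromatic carbon, a change that brought a 1.2-fold higher number from compound 1 to compound 3 (0.06 log units; within the scatter). Between the two substituted analogues there is a 3.0-fold higher number from compound 2 to compound 3 (0.47 log units; beyond the scatter).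

Compound 4, `COc1ccc(/C=C/C(=O)Nc2nnc(-c3ccc(Cl)cc3)s2)cc1`, has not yet been measured. It differs from compound 3 in methoxy in place of hydrogen on an aromatic carbon, the same change that turned compound 1 into compound 2, made at the same kind of place on the same ring, so it is the same change on a chloro-bearing core. Because of a 2.6-fold lower number from compound 1 to compound 2 (0.41 log units; beyond the scatter), the expected step is a 2.5-fold lower number from compound 3 to compound 4 (0.40 log units; beyond the scatter). As far as these compounds go, this rests on a single earlier example, and whether the chloro on the other ring alters the outcome is unknown, so the range is wide. Compound 4 is estimated at 0.8 ug/mL, between 0.4 ug/mL and 1.6 ug/mL.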

Compound 4, half-maximal inhibitory concentration: 1.38 ug/mL
For compound 4 the middle estimate is 1.7-fold (0.24 log units) below the measured one; low and high end bracket the measured number.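

In this assay, adding the methoxy group to the chloro-bearing core gave a 1.5-fold lower number from compound 3 to compound 4 (0.17 log units; within the scatter), so on this core the step alone cannot be told apart from the ordinary spread of repeated measurements. Set beside the earlier case, the two steps do not differ by more than that spread allows: the same change on two cores in this assay, a 2.6-fold lower number (0.41 log units; beyond the scatter) from compound 1 to compound 2 and a 1.5-fold lower number (0.17 log units; within the scatter) from compound 3 to compound 4, 1.8-fold (0.25 log units) apart, within the scatter of two such steps. Within the data shown here, this fits the idea that the change carries over from one core to the other, but it does not prove it: there are only two examples, one of them is too small to count as a real change by itself, and neither says why the number moves.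

The compounds shown leave open whether other groups at this place, such as an amine, a carboxylic acid or a longer chain like ethoxy, would behave in the same way. They also leave open whether the methoxy step would hold on cores carrying other substituents or in any other assay.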